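A Fluoro Step at the Assay Limit

The source may hold more compounds than are shown below. What is called first, only, known or untested is meant among the compounds shown, and "the series" means these compounds.

Compound 1 `C=C[C@@](C)(/C=C/c1ccc(O)c(/C=C/C#N)c1)CCC=C(C)C`: > 43400 nM
Compound 2 `C=C[C@@](C)(/C=C/c1ccc(Nc2ccccc2)cc1)CCC=C(C)C`: > 43400 nM
Compound 3 `C=C[C@@](C)(/C=C/c1ccc(Nc2cccc(OC(F)(F)F)c2)cc1)CCC=C(C)C`: > 43400 nM

These three entries from a functional assay on NALM-6 cells (Homo sapiens) for cytotoxicity, with a stated time of 72 h (a lower number here means that less compound is needed, a higher number that more compound is needed for the effect), are limits, not numbers, and the picture is uniform: the limit of > 43400 nM in this assay, at which 3 of the 3 values shown sit. Compound 2 therefore has a limit as its only standing. Compound 4 `C=C[C@@](C)(/C=C/c1ccc(Nc2ccc(F)cc2)cc1)CCC=C(C)C` has fluoro in place of hydrogen on an aromatic carbon. Among the measured compounds shown here, one measured step bears on this change, trifluoromethoxy in place of hydrogen on an aromatic carbon, and it is a step that the two limits leave unreadable from compound 2 to compound 3. With no readable size from that step, no change beyond the scatter is expected in this assay. The expected step is a step that the limit leaves unreadable from compound 2 to compound 4. For compound 4 the estimate is 45000 nM, with an expected range of 15000 nM to 90000 nM.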

Compound 4, half-maximal effective concentration: > 43400 nM
Compound 4 ended at the assay's limit; the forecaster's own chance of this, stated with the estimate: 80%; the middle value is on the limit's open side.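

Compound 2 and compound 4 both stand as limits, so no size can be read for the fluoro change between them: the limit of > 43400 nM in this assay, at which 4 of the 4 values shown sit.

The compounds shown leave open whether any substituent on the anilino ring changes the value, and how the four compounds rank.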